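The compounds below may be only part of what the source reports. "The series", "measured", "known", "first", "only" and "open" are said of these compounds alone.

Of the compounds shown here, two with a shared core have been tested in a functional assay on B16 cells (Mus musculus) for antiproliferative activity, read by MTT assay, with a stated time of 24 h; a lower number here means a stronger inhibitor, a higher number a weaker inhibitor. Compound 1 `COc1cc(OC)c(-c2coc3cc(OCC=C(C)C)ccc3c2=O)cc1OC`, with a 2-methylprop-1-en-1-yl group on a saturated chain carbon bound to an oxygen on an aromatic ring, gives 1090 nM. Compound 2 `C=CCOc1ccc2c(=O)c(-c3cc(OC)c(OC)cc3OC)coc2c1`, with vinyl in that place, gives 5100 nM, the higher and therefore weaker of the two numbers.

Compound 3 `C#CCOc1ccc2c(=O)c(-c3cc(OC)c(OC)cc3OC)coc2c1` has not yet been measured. It differs from compound 2 in one place: ethynyl in place of vinyl on a saturated chain carbon bound to an oxygen on an aromatic ring. Ethynyl stands in place of vinyl on the same saturated chain carbon, so allyloxy becomes propargyloxy.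

Among the measured compounds shown here, only one measured step bears on this change: a 4.7-fold higher number from compound 1 to compound 2 (0.67 log units; beyond the scatter), which is modest but beyond the scatter. It shows that this part of the molecule can move the number. However, it involves a different pair of groups, and no measured pair compares a double bond with a triple bond. No step beyond the scatter is therefore expected in this assay, and no direction can be favoured with confidence.

The expected change is a 1.1-fold lower number from compound 2 to compound 3 (0.05 log units; within the scatter). Compound 3 is estimated at 4500 nM, with an expected range from 1800 nM to 11000 nM.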

Compound 3, half-maximal inhibitory concentration: 4500 nM
Compound 3: the middle estimate sits on the measured number at the digits printed; the range from low to high includes it.
By their numbers in this assay, from the lowest: compound 1; then compounds 3 and 2 (each within the scatter of the next).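

In this assay, the step from the double bond of allyloxy to the triple bond of propargyloxy gives a 1.1-fold lower number from compound 2 to compound 3 (0.05 log units; within the scatter) and so does not separate the two groups at this position. The larger gap remains on the other side, where ethynyl in place of 2-methylprop-1-en-1-yl gives a 4.1-fold higher number from compound 1 to compound 3 (0.62 log units; beyond the scatter) and leaves compound 1 with the lowest number of the three, since its step to compound 2 is also beyond the scatter. Nothing measured alongside these numbers offers a cause for either result.

The compounds shown leave open whether the lower number of compound 1 belongs to the 2-methylprop-1-en-1-yl group in particular or would also appear with another group at this place, such as a longer saturated chain or a benzyl group. They also leave open whether a double or triple bond matters here at all, a question that an ethyl group on the same saturated chain carbon, with no such bond, would address.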